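This account rests on a few compounds, and the source may have more. Where it says the series, first, only, none or still open, it means among the compounds named here.

In a functional assay on the whole organism for inhibition, with Lepidium sativum as the target, tested at 1 ppm (a lower number here means less inhibition of growth, a higher number more inhibition of growth at the concentration tested), compound 1 `COC(=O)C(C)ON1C(=O)c2ccccc2C1=O` gives 64%, the highest of the three numbers in hand. Compound 2 `CCOC(=O)C(Cc1ccccc1)ON1C(=O)c2ccccc2C1=O` gives 0%, and compound 3 `CCOC(=O)C(CC)ON1C(=O)c2ccccc2C1=O` gives 0%; both lie far below compound 1, beyond the scatter. For the measured compounds named here, the only step measured in a single place, no change at the digits printed from compound 2 to compound 3 (within the scatter), concerns the substituent on the chain carbon and leaves the ester group untouched. Compound 4 `CCCCCOC(=O)C(C)ON1C(=O)c2ccccc2C1=O` differs from compound 1 by butyl in place of hydrogen on a saturated chain carbon bound to an oxygen next to a carbonyl group. Going by the values given here, no measured pair isolates a change of the ester alkyl: compound 1 and compound 3 differ in two places at once, so the gap between compound 1 at 64% and compound 3 at 0% cannot be assigned to either change alone. With nothing measured that bears directly on this change, the step of a number 24 percentage points lower from compound 1 to compound 4 (beyond the scatter) is expected to be a moderate drop, with wide uncertainty in both directions. Compound 4 is therefore estimated at 40%, in a range from 5% to 75%.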

Compound 4, percent growth inhibition at one concentration: 64%
Compound 4: middle estimate off by 24 percentage points, on the low side; low and high end bracket the measured number.
By their numbers in this assay, from the lowest: compounds 2 and 3 (each within the scatter of the next); then compounds 1 and 4 (each within the scatter of the next).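

In this assay, for the compounds shown here, the step of no change at the digits printed from compound 1 to compound 4 (within the scatter) gives the first reading of a change at the ester alkyl alone, as the only earlier step concerned the substituent on the chain carbon. Read as methoxy to pentyloxy, the change shows that this position accepts butyl in place of hydrogen with no loss of growth inhibition at the concentration tested. Nothing available explains why the number holds across this change.

The compounds shown leave open whether this tolerance extends to a longer chain such as decyl, or to a carboxylic acid in place of the ester. They also leave open whether pentyloxy would give the same result on a core carrying a different substituent on the chain carbon.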